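Replacing Azidomethyl with (Pyrrolidin-1-yl)carbonyl

The source may hold more compounds than are shown below. What is called first, only, known or untested is meant among the compounds shown, and "the series" means these compounds.

In a functional assay on SW480 cells (Homo sapiens) for antiproliferative activity, read by MTT assay, with a stated time of 48 h (on this read-out lower numbers stand for stronger inhibition and higher numbers for weaker inhibition), compound 1 (`COC/C1=C/C[C@](C)(CCC=C(C)C)/C=C/[C@@H](OC(=O)C=C(C)C)[C@](C)(O)/C=C/C1=O`) gives 3850 nM, compound 2 (`CC[Si](CC)(CC)C/C1=C/C[C@](C)(CCC=C(C)C)/C=C/[C@@H](OC(=O)C=C(C)C)[C@](C)(O)/C=C/C1=O`) gives 2690 nM and compound 3 (`CC(C)=CCC[C@]1(C)/C=C/[C@@H](OC(=O)C=C(C)C)[C@](C)(O)/C=C/C(=O)/C(CN=[N+]=[N-])=C\C1`) gives 4230 nM, so compound 3 stands within the scatter of both others. Compound 4 (`CC(C)=CCC[C@]1(C)/C=C/[C@@H](OC(=O)C=C(C)C)[C@](C)(O)/C=C/C(=O)/C(C(=O)N2CCCC2)=C\C1`) carries (pyrrolidin-1-yl)carbonyl in place of azidomethyl on a double-bonded ring carbon. The closest evidence is a 1.1-fold higher number from compound 1 to compound 3 (0.04 log units; within the scatter) and a 1.6-fold higher number from compound 2 to compound 3 (0.20 log units; within the scatter), both within the scatter, as is a 1.4-fold lower number from compound 1 to compound 2 (0.16 log units; within the scatter). These steps leave the saturated chain carbon in place, so they bear on this change only in part. No step beyond the scatter is therefore expected. The estimated step is a 1.1-fold lower number from compound 3 to compound 4 (0.02 log units; within the scatter). Compound 4 is expected at 4000 nM, with an estimated range of 1700 nM to 9500 nM.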

Compound 4, half-maximal inhibitory concentration: 15100 nM
The estimate for compound 4 lay 3.8-fold (0.58 log units) below the measured number; the whole stated range lies below it.
By their numbers in this assay, from the lowest: compounds 2, 1 and 3 (each within the scatter of the next); then compound 4.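

In this assay, within the data shown here, the double-bonded ring carbon shows a step beyond the scatter for the first time: (pyrrolidin-1-yl)carbonyl in place of azidomethyl gives a 3.6-fold higher number from compound 3 to compound 4 (0.55 log units; beyond the scatter) and in place of methoxymethyl gives a 3.9-fold higher number from compound 1 to compound 4 (0.59 log units; beyond the scatter), while in place of the silicon-bearing group it gives a 5.6-fold higher number from compound 2 to compound 4 (0.75 log units; beyond the scatter). Among these compounds, the three earlier groups had stayed within the scatter of one another, so this is the first change here that weakens inhibition. Nothing at hand accounts for this step.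

From the compounds shown here alone, whether the step goes with the carbonyl or with the pyrrolidine ring stays open. A (pyrrolidin-1-yl)methyl group or a carboxylic acid on this carbon would separate the two.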